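The source may report more compounds than this note shows. Statements on the series, on what has been measured and on what is new or still open speak of the compounds shown alone.

Working notes on the series: in a functional assay on L1210 cells (Mus musculus) for inhibition (a higher number here means a weaker inhibitor, a lower number a stronger inhibitor), compound 2 (`CC(=O)CC1C[C@@H](CCCCCCCC#C[C@H](O)COCCOC[C@H](O)c2ccccc2)OC1=O`) gives 21600 nM, the only actual number so far. Compound 1 (`COc1ccc([C@H](O)COCCOC[C@H](O)C#CCCCCCCC[C@@H]2CC(CC(C)=O)C(=O)O2)cc1`) reads > 10000 nM, which is a limit of the assay. Next comes compound 3 (`COc1ccc([C@@H](O)COCCOC[C@@H](O)C#CCCCCCCC[C@@H]2CC(CC(C)=O)C(=O)O2)cc1`), with methoxy in place of hydrogen on an aromatic carbon, para to a large group: methoxy in place of hydrogen on an aromatic carbon. Among the compounds with values here, no measured step covers this change, so the expectation in this assay is no shift beyond the scatter, with neither direction favoured. The expected step is a 1.1-fold lower number from compound 2 to compound 3 (0.03 log units; within the scatter). Compound 3 is estimated at 20000 nM, with an expected range of 8000 nM to 55000 nM.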

Compound 3, half-maximal inhibitory concentration: 32000 nM
Beside the measured number, compound 3's estimate is 1.6-fold (0.20 log units) below it, within the range that was stated.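

In this assay, methoxy in place of hydrogen on an aromatic carbon, para to a large group, gives a 1.5-fold higher number from compound 2 to compound 3 (0.17 log units; within the scatter), so the change from phenyl to 4-methoxyphenyl shows no shift beyond the scatter. Compound 1 carries a limit and not a number, so its step to compound 3 cannot be read: the limit of > 10000 nM in this assay, at which 1 of the 3 values shown sits.

From the compounds shown here alone, whether the two stereocentres that differ between compound 1 and compound 3 affect the number stays open. Also open, going by these compounds, is whether an amine or a carboxylic acid at this position would move the number beyond the scatter.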